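Aryl swap at the shared core: pyrrole for pyridine

A few compounds are considered here, and "the series" means these few. Any claim that something is new, unique, unknown or untested is made for them only; others in the source may bear on it.

Compound 2 `OC[C@H]1OC(n2cnc3c(-c4ccccn4)ncnc32)[C@H](O)[C@@H]1O` gives 900 nM in a functional assay on CCRF-CEM cells (Homo sapiens) for inhibition (on this read-out higher numbers stand for weaker inhibition and lower numbers for stronger inhibition), and holds the lowest of the two numbers measured. For the measured compounds named here, its nearest neighbour, compound 1 `Cc1csc(-c2ncnc3c2ncn3C2O[C@H](CO)[C@@H](O)[C@H]2O)n1`, gives 6000 nM in this assay; the step of a 6.7-fold lower number from compound 1 to compound 2 (0.82 log units; beyond the scatter) is the single measured step, and it replaces a five-membered heteroaryl by a six-membered one on the shared core. Compound 3 `Cn1cccc1-c1ncnc2c1ncn2C1O[C@H](CO)[C@@H](O)[C@H]1O` differs from compound 2 by 1-methyl-1H-pyrrol-2-yl in place of pyridin-2-yl on an aromatic carbon. Going by the values given here, this change runs the other way from the measured step, taking the six-membered heteroaryl back out in favour of a five-membered one, though the entering ring is not the one that left in compound 1. The earlier step is therefore taken as a loose guide, not a direct one; its size marks the outer bound of what a ring change at this position has done so far. The expectation for compound 3 in this assay is a modest rise in number, the step of a 2.8-fold higher number from compound 2 to compound 3 (0.44 log units; beyond the scatter) from compound 2 to compound 3 being expected to be smaller than the measured one. Compound 3 is estimated at 2500 nM, with a range from 800 nM to 8000 nM.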

Compound 3, half-maximal inhibitory concentration: 2000 nM
Estimate against measurement, compound 3: 1.3-fold (0.10 log units) above; low and high end bracket the measured number.
By their numbers in this assay, from the lowest: compound 2; then compound 3; then compound 1.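

Swapping pyridin-2-yl for 1-methyl-1H-pyrrol-2-yl keeps the same counts of heavy atoms, hetero atoms, donors and acceptors in the entering and leaving groups, yet in this assay the change still gives a 2.2-fold higher number from compound 2 to compound 3 (0.35 log units; beyond the scatter) and lies beyond the scatter. The two five-membered groups are also separated, with a 3.0-fold lower number from compound 1 to compound 3 (0.48 log units; beyond the scatter) as the step between them, so ring size alone does not set the number at this aromatic carbon: 1-methyl-1H-pyrrol-2-yl and 4-methyl-1,3-thiazol-2-yl give different results on the shared core, although among these three compounds the six-membered pyridin-2-yl remains the one with the lowest number. No measurement shown here accounts for any of these differences.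

Open questions remain about how an amine, a plain phenyl ring or a longer alkyl chain on this aromatic carbon would read in this assay, as all three groups shown are aromatic heterocycles. Also open, as far as these compounds go, is what part the methyl group plays in each five-membered ring, as neither the 1-methyl-1H-pyrrol-2-yl nor the 4-methyl-1,3-thiazol-2-yl group appears here beside a counterpart without its methyl.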